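The source may report more compounds than this note shows. Statements on the series, on what has been measured and on what is new or still open speak of the compounds shown alone.

Three compounds that share one core have been examined in an ADME assay on microsomes from liver (Mus musculus) for metabolic stability, read by LC-MS, with a stated time of 30 min, tested at 1 uM; on this read-out lower numbers stand for a less stable compound and higher numbers for a more stable compound. Compound 1 `Cn1c(C(=O)NCc2ccc(S(=O)(=O)c3ccccc3)cc2)cc2ccncc21` returns "below limit of detection" (no number reported), an entry for which no number is reported. Compound 2 `O=C(NCc1ccc(S(=O)(=O)c2ccccc2C(F)(F)F)cc1)c1cc2cnccc2[nH]1` gives 41%, the lower of the two numbers obtained so far. Compound 3 `O=C(NCc1ccc(S(=O)(=O)c2cccc(C(F)(F)F)c2)cc1)c1cc2ccncc2o1` gives 64%, a reading that stands beyond the usual scatter above compound 2. Compound 4 `Cc1ccccc1S(=O)(=O)c1ccc(CNC(=O)c2cc3cnccc3[nH]2)cc1` has not yet been measured in this assay; it differs from compound 2 in a single place: methyl in place of trifluoromethyl on an aromatic carbon. Within the data shown here, no measured pair shows this particular change, so its effect is not known from these data. The step of a number 9 percentage points lower from compound 2 to compound 4 (within the scatter) is expected, that is, a change within the scatter or a modest downward move. Compound 4 is estimated at 32%, between 10% and 55%.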

Compound 4, percent of the compound remaining: 15%
Estimate against measurement, compound 4: 17 percentage points above, within the range that was stated.
By their numbers in this assay, from the lowest: compound 4; then compound 2; then compound 3.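

In this assay, among these compounds, methyl in place of trifluoromethyl on this aromatic carbon, ortho to a large group, brings a number 26 percentage points lower from compound 2 to compound 4 (beyond the scatter) and gives the first one-place comparison in this set. It shows that the group at this position matters for the read-out, with the trifluoromethyl compound the more stable of the pair. No measurement shown gives a reason for this step. As far as these compounds go, how chlorine or a methoxy group at this position would compare remains open, as does whether the same change would have a similar effect on the core of compound 3.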